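A few compounds are considered here, and "the series" means these few. Any claim that something is new, unique, unknown or untested is made for them only; others in the source may bear on it.

Compound 1 `COCCOC(=O)Nc1cc2nc(C3CCCCC3)[nH]c2cc1N1CCCC1`: > 100 ug/mL; compound 2 `COc1ccc(C(=O)Nc2cc3nc(C4CCCCC4)[nH]c3cc2N(C)C)cc1`: > 100 ug/mL; compound 3 `CCCOCC(=O)Nc1cc2nc(C3CCCCC3)[nH]c2cc1N(C)C`: < 50 ug/mL.

In an ADME assay on Vero cells (Chlorocebus sabaeus) for cytotoxicity, read by resazurin assay, with a stated time of 3 days (on this read-out lower numbers stand for stronger inhibition and higher numbers for weaker inhibition), compound 1 reaches only a limit, > 100 ug/mL. Compound 2 likewise reaches only a limit, > 100 ug/mL. Compound 3 is reported only as a limit as well, < 50 ug/mL, so it stands at the lower of the two limits seen in this set. Among the measured compounds shown here, the one measured step, an at least 2.0-fold lower number from compound 2 to compound 3 (0.30 log units; that floor lies within the scatter), runs from the limit of > 100 ug/mL in this assay, at which 2 of the 3 values shown sit, to the limit of < 50 ug/mL in this assay, at which 1 of the 3 values shown sits. Compound 4 `CCCCNC(=O)Nc1cc2nc(C3CCCCC3)[nH]c2cc1N(C)C` differs from compound 3 by butylamino in place of propoxymethyl on a carbonyl carbon. For the measured compounds named here, no measured step involves a butylamino group, so nothing here bears directly on this change, and no step beyond the scatter is expected. Compound 4 is therefore expected to give about 60 ug/mL, between 25 ug/mL and 150 ug/mL, which amounts to an at least 1.2-fold higher number from compound 3 to compound 4 (0.07 log units; that floor lies within the scatter).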

Compound 4, half-maximal inhibitory concentration: > 100 ug/mL
Compound 4: no number, only a limit; the forecaster's own chance of this, stated with the estimate: 60%; middle value at least 1.6-fold (0.22 log units) from the limit.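

In this assay, butylamino in place of propoxymethyl on a carbonyl carbon gives an at least 2.0-fold higher number from compound 3 to compound 4 (0.30 log units; that floor lies within the scatter). Compound 4 is reported only as a limit, the upper one in this set: the limit of > 100 ug/mL in this assay, at which 3 of the 4 values shown sit. The step between compound 2 and compound 4 cannot be read, as both values are limits.

The compounds shown leave open how far compound 3 and compound 4 really lie apart. They also leave open whether a longer ether chain or a primary amine on this carbonyl carbon would give the lower limit or the upper one.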